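The source may report more compounds than this note shows. Statements on the series, on what has been measured and on what is new or still open speak of the compounds shown alone.

In a functional assay on CHO cells for positive allosteric modulation of muscarinic acetylcholine receptor M5 (Homo sapiens), read by FLIPR and calcium flux, with a stated time of 1 h (on this read-out higher numbers stand for an effect only at larger amounts of compound and lower numbers for an effect already at smaller amounts), compound 1 `O=C1C(=O)N(Cc2ccc(-c3cncnc3)cc2)c2ccc(OC(F)(F)F)cc21` gives 2100 nM, the lowest of the three numbers recorded. Compound 3 `O=C1C(=O)N(Cc2ccc(-c3ccncc3)nc2)c2ccc(OC(F)(F)F)cc21` gives 4400 nM and compound 2 `O=C1C(=O)N(Cc2ccc(Br)cc2)c2ccccc21` gives 4600 nM; each gap to compound 1 lies beyond the usual scatter, so compound 1 is the most potent of the measured set. Among the compounds with values here, no two measured compounds differ in a single place, so no measured step is available as a guide. Compound 4 `O=C1C(=O)N(Cc2ccc(Oc3nccs3)cc2)c2ccc(OC(F)(F)F)cc21` has not yet been measured; it differs from compound 1 by (1,3-thiazol-2-yl)oxy in place of pyrimidin-5-yl on an aromatic carbon. With nothing to anchor this change, only a modest step is expected, a 1.2-fold higher number from compound 1 to compound 4 (0.08 log units; within the scatter) in this assay, without a clear direction beyond the scatter. Compound 4 is therefore estimated at 2500 nM, with a range from 900 nM to 7000 nM.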

Compound 4, half-maximal effective concentration: 2800 nM
Compound 4: middle estimate off by 1.1-fold (0.05 log units), on the low side; the range from low to high includes it.
By their numbers in this assay, from the lowest: compounds 1, 4, 3 and 2 (each within the scatter of the next, the first and the last beyond it).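

In this assay, within the data shown here, (1,3-thiazol-2-yl)oxy in place of pyrimidin-5-yl gives a 1.3-fold higher number from compound 1 to compound 4 (0.12 log units; within the scatter), the first step read between compounds that differ in one place. This place, on the aromatic carbon para to a large group, therefore takes a five-membered aromatic ring joined through oxygen as well as a six-membered aromatic ring, with the two compounds within the scatter of each other. Nothing measured here explains why the two groups read alike. The compounds shown leave open how a carboxylic acid or an amine at this place would read.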